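The source may hold more compounds than are shown below. What is called first, only, known or untested is meant among the compounds shown, and "the series" means these compounds.

In a functional assay on SW-620 cells (Homo sapiens) for cytotoxicity, read by MTT assay, with a stated time of 72 h (a higher number here means a weaker inhibitor, a lower number a stronger inhibitor), compound 1 `COc1ccc(/C=C2\CCC/C(=C\c3ccccc3Cl)C2=O)cc1OC` gives 7100 nM and compound 2 `COc1ccc(/C=C2\CCC/C(=C\c3cccc(Br)c3)C2=O)cc1OC` gives 4200 nM, so these two values lie within the usual scatter of each other. Compound 3 `COc1ccc(/C=C2\CCC/C(=C\c3cccc(O)c3)C2=O)cc1OC` shares the core of compound 2 but has hydroxy in place of bromo on an aromatic carbon. Within the data shown here, the one measured step bearing on this change, a 1.7-fold lower number from compound 1 to compound 2 (0.23 log units; within the scatter), did not involve hydroxy, so it offers only limited guidance. No shift beyond the scatter is therefore expected, and the expected step is a 1.1-fold lower number from compound 2 to compound 3 (0.02 log units; within the scatter). Compound 3 is estimated at 4000 nM, with an expected range of 1500 nM to 10000 nM.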

Compound 3, half-maximal inhibitory concentration: 1900 nM
Beside the measured number, compound 3's estimate is 2.1-fold (0.32 log units) above it, and the stated range covers the measured number.
By their numbers in this assay, from the lowest: compound 3; then compounds 2 and 1 (each within the scatter of the next).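

Hydroxy in place of bromo on this aromatic carbon gives a 2.2-fold lower number from compound 2 to compound 3 (0.34 log units; beyond the scatter) in this assay, the first single change here to move the number beyond the scatter, though only modestly. The 3-hydroxyphenyl group also separates from 2-chlorophenyl, with a 3.7-fold lower number from compound 1 to compound 3 (0.57 log units; beyond the scatter), whereas 3-bromophenyl and 2-chlorophenyl did not separate.

On these data alone, whether an amine or a carboxylic acid on the same carbon would lower the number further remains open. Nothing measured here accounts for the shift with hydroxy.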